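This account rests on a few compounds, and the source may have more. Where it says the series, first, only, none or still open, it means among the compounds named here.

Compound 1 `Cn1c(-c2ccc(NC(=O)CCl)cc2)nc(-c2ccccc2)c1-c1ccccc1` is the smallest member of the series, with a chloro group on a saturated chain carbon bound to a carbonyl carbon. Going by the values given here, in a functional assay on MCF7 cells (Homo sapiens) for cytotoxicity, read by MTT assay, with a stated time of 24 h, tested at 16 ug/mL (a lower number here means a weaker effect, a higher number a stronger effect of the compound at the concentration tested), compound 1 gives 15.2%, the lowest of the two numbers measured so far. Among the compounds with values here, compound 2 `Cn1c(-c2ccc(NC(=O)CSC3=NCCS3)cc2)nc(-c2ccccc2)c1-c1ccccc1` keeps the shared core and in this assay compound 2 gives 41.8%; the single measured step, a number 26.6 percentage points higher from compound 1 to compound 2 (beyond the scatter), shows that replacing the chloro at that carbon by a larger ring-bearing group moved the read-out upward. Compound 3 `CN(C)/C=C/N1CCN(CC(=O)Nc2ccc(-c3nc(-c4ccccc4)c(-c4ccccc4)n3C)cc2)CC1` has not yet been measured in this assay. Against compound 1 the change is 4-(2-(dimethylamino)ethenyl)piperazin-1-yl in place of chloro on a saturated chain carbon bound to a carbonyl carbon — again a ring-bearing group entering at the same saturated chain carbon in place of chloro, though a different one from that in compound 2. Within the data shown here, the only step that bears on it is the one from compound 1 to compound 2, modest and beyond the scatter, so a rise of comparable size is expected, namely a number 19.8 percentage points higher from compound 1 to compound 3 (beyond the scatter). Compound 3 is therefore estimated at 35%, within a range from 15% to 58%.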

Compound 3, a percentage reported as activity, at one concentration (the size of the read-out at that concentration, not a potency): 19.4%
Compound 3: middle estimate off by 15.6 percentage points, on the high side; measured number inside the range.
By their numbers in this assay, from the lowest: compounds 1 and 3 (each within the scatter of the next); then compound 2.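

In this assay, the step with 4-(2-(dimethylamino)ethenyl)piperazin-1-yl in place of chloro, a number 4.2 percentage points higher from compound 1 to compound 3 (within the scatter), shows that a ring-bearing group on this saturated chain carbon does not by itself set a compound apart from the chloro compound. The step of a number 22.4 percentage points lower from compound 2 to compound 3 (beyond the scatter) shows that the read-out at this position depends on which ring-bearing group enters: of the two tried, only the five-membered, sulfur-containing group of compound 2 stands beyond the scatter from compound 1. No measurement at hand gives a reason for the difference between these two groups.

The compounds shown leave open whether the higher number of compound 2 goes with its sulfur atoms or with its five-membered ring, a question that an open-chain thioether such as methylthio or a morpholine on the same carbon could help to separate. On these data alone, it is also open whether the 2-(dimethylamino)ethenyl part matters in compound 3, which an unsubstituted piperazine in the same place would test.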